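Aryl amine in place of oxanyl amine on the core

The compounds below may be only part of what the source reports. "The series", "measured", "known", "first", "only" and "open" are said of these compounds alone.

For the measured compounds named here, compound 1 `Cc1cc(-c2cnn3c(NCC4CCOCC4)nc(NC4CCOCC4)nc23)ccc1C(=O)NC1CC1` is one of two compounds measured in a functional assay on HCT-116 cells (Homo sapiens) for antiproliferative activity (a lower number here means a stronger inhibitor of growth, a higher number a weaker inhibitor of growth), where compound 1 gives 280 nM. Its only comparator, compound 2 `O=C(NC1CC1)c1ccc(-c2cnn3c(NCC4CCOCC4)nc(Oc4ccccc4)nc23)cc1`, carries a phenoxy group and lacks the methyl group; in this assay compound 2 gives 200 nM. Going by the values given here, compound 1 has the higher of the two numbers, but the two values lie within the scatter of each other, so nothing can be read from the gap between them, and no single-point step between measured compounds is available.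

Compound 3 `Cc1cc(-c2cnn3c(NCC4CCOCC4)nc(Nc4ccccc4F)nc23)ccc1C(=O)NC1CC1` differs from compound 1 in one place: 2-fluorophenyl in place of oxan-4-yl on a nitrogen on an aromatic ring. Among the compounds with values here, compound 2 shows that an aromatic ring at this position of the shared core is compatible with activity in this assay, which is the only guide to the step. The expected change from compound 1 to compound 3 in this assay is therefore small, a 1.4-fold lower number from compound 1 to compound 3 (0.15 log units; within the scatter), and not beyond the scatter in either direction. Compound 3 is expected to give about 200 nM in this assay, with a plausible range from 70 nM to 600 nM.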

Compound 3, concentration for 50% growth inhibition: 21 nM
Compound 3: the middle estimate sits 9.5-fold (0.98 log units) above what was measured; measured number below the stated range.
By their numbers in this assay, from the lowest: compound 3; then compounds 2 and 1 (each within the scatter of the next).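

In this assay, the group on this nitrogen has a large effect on the number: 2-fluorophenyl in place of oxan-4-yl gives a 13-fold lower number from compound 1 to compound 3 (1.12 log units; beyond the scatter), a step beyond the scatter. For the compounds shown here, this is the first single-place step, as compound 1 and compound 2 differ in more than one place and could only suggest that an aromatic ring at this position is compatible with activity. Compound 3 now shows that the change from (oxan-4-yl)amino to (2-fluorophenyl)amino can be worth far more than the gap between those two earlier compounds implied, although nothing at hand explains the size of the step.

The step exchanges the whole group at once, so it does not separate the contribution of the fluorine from that of the aromatic ring or of the loss of the oxan-4-yl ring oxygen; phenyl without fluorine and cyclohexyl on the same nitrogen would divide these contributions. On these data alone, whether the step would keep its size on the shared core without the methyl group of compound 1 also remains open.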